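A few compounds are considered here, and "the series" means these few. Any claim that something is new, unique, unknown or untested is made for them only; others in the source may bear on it.

Compound 1 `CC1=C(C(=O)SC(C)(C)C)C(c2ccccc2)C=C(c2ccccc2)N1`: 95800 nM
Compound 2 `CCOC(=O)C1=C(C)NC(c2ccc(Cl)cc2)=CC1c1ccccc1`: 9300 nM
Compound 3 `CCOC(=O)C1=C(C)NC(c2ccc(Cl)cc2)=CC1c1ccc(Cl)cc1`: 28400 nM

In an assay on SH-SY5Y cells for inhibition of Voltage-dependent L-type calcium channel subunit alpha-1D (Homo sapiens), read by calcium flux, with a stated time of 15 min (a higher number here means a weaker inhibitor, a lower number a stronger inhibitor), compound 3 gives 28400 nM, the second highest of the three numbers; compound 2 sits at 9300 nM and compound 1 at 95800 nM. Compound 4 `CCOC(=O)C1=C(C)NC(c2ccc(Cl)cc2)=CC1c1cccc(OC)c1` differs from compound 3 by 3-methoxyphenyl in place of 4-chlorophenyl on a saturated ring carbon. For the measured compounds named here, only one measured step touches this position: a 3.1-fold higher number from compound 2 to compound 3 (0.48 log units; beyond the scatter), a modest move. That step covers the loss of the chloro, but nothing measured speaks to a methoxy entering at the new position. On this basis a modest step back toward the number of compound 2 is expected for compound 4, namely a 2.0-fold lower number from compound 3 to compound 4 (0.31 log units; beyond the scatter), with wide uncertainty. Compound 4 is therefore estimated at 14000 nM, within a range of 4500 nM to 45000 nM.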

Compound 4, half-maximal inhibitory concentration: 15100 nM
Compound 4: middle estimate off by 1.1-fold (0.03 log units), on the low side, within the range that was stated.
By their numbers in this assay, from the lowest: compounds 2, 4 and 3 (each within the scatter of the next, the first and the last beyond it); then compound 1.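

In this assay, the first oxygen-bearing substituent on this aryl ring gives a step that stays within the scatter in both available comparisons: 3-methoxyphenyl against 4-chlorophenyl (a 1.9-fold lower number from compound 3 to compound 4 (0.27 log units; within the scatter)) and methoxy against hydrogen (a 1.6-fold higher number from compound 2 to compound 4 (0.21 log units; within the scatter)). Unlike the chloro step, the methoxy step therefore does not separate the substituted compound from the unsubstituted phenyl compound. Nothing shown gives a reason for either result.

The compounds shown leave open whether 4-methoxyphenyl or 3-chlorophenyl would read like compound 4 at this ring carbon. They also leave open what an amine or a carboxylic acid on this aryl ring would do.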